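Halogen Swap on a Cyclohexanone Dibenzylidene Scaffold

The source may hold more compounds than are shown below. What is called first, only, known or untested is meant among the compounds shown, and "the series" means these compounds.

Measured so far in an assay on isolated protein for inhibition of Alpha glucosidase (Homo sapiens), with stated times of 5 min and 15 min, tested at 50 uM; on this read-out lower numbers stand for less inhibition and higher numbers for more inhibition at the one concentration tested (going by the name of the read-out):
compound 1 `O=C1/C(=C/c2ccccc2)CCC/C1=C\c1cccc(Br)c1`: 27.2%
compound 2 `O=C1/C(=C/c2ccccc2)CCC/C1=C\c1ccc(Cl)cc1`: 27.6%
compound 3 `O=C1/C(=C/c2ccccc2)CCC/C1=C\c1ccc(Br)cc1`: 29.1%

The three numbers sit close together. Compound 3 gives the highest of them, yet the step of a number 1.5 percentage points higher from compound 2 to compound 3 (within the scatter) and the step of a number 1.9 percentage points higher from compound 1 to compound 3 (within the scatter) both lie within the scatter, so no ranking among the three can be read from this assay. The step of a number 0.4 percentage points higher from compound 1 to compound 2 (within the scatter) is likewise within the scatter.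

Compound 4 `O=C1/C(=C/c2ccccc2)CCC/C1=C\c1ccccc1F` is not yet measured. It differs from compound 3 by 2-fluorophenyl in place of 4-bromophenyl on a double-bonded chain carbon bound to a double-bonded ring carbon. Going by the values given here, two measured steps bear on this change: exchanging one halogen for another (a number 1.5 percentage points higher from compound 2 to compound 3 (within the scatter)) and moving the halogen around the ring (a number 1.9 percentage points higher from compound 1 to compound 3 (within the scatter)) each left the number within the scatter. Among the compounds with values here, no measured compound carries a fluorine or a substituent at that ring position, so the change to compound 4 reaches beyond what has been seen, but nothing in the data points to a step beyond the scatter.

Compound 4 is therefore expected to give about 27%, with a range from 17% to 37%. The expected step is a number 2.1 percentage points lower from compound 3 to compound 4 (within the scatter), which stays within the scatter.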

Compound 4, a percentage reported as inhibition, at one concentration (the size of the read-out at that concentration, not a potency): 43%
For compound 4 the middle estimate is 16 percentage points below the measured one; the whole stated range lies below it.
By their numbers in this assay, from the lowest: compounds 1, 2 and 3 (each within the scatter of the next); then compound 4.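

Compounds 1, 2 and 3 stayed within the scatter of each other, but in this assay 2-fluorophenyl shows that the number can respond to the group at this position, on a double-bonded chain carbon bound to a double-bonded ring carbon. In place of 4-bromophenyl it gives a number 13.9 percentage points higher from compound 3 to compound 4 (beyond the scatter) and in place of 4-chlorophenyl it gives a number 15.4 percentage points higher from compound 2 to compound 4 (beyond the scatter) while in place of 3-bromophenyl it gives a number 15.8 percentage points higher from compound 1 to compound 4 (beyond the scatter) so all three steps point the same way. Nothing available explains why this group stands apart from the other three.

The change alters both the halogen and where it sits on the ring, and the compounds shown do not separate those two effects. Also open, on these data alone, is how a group other than a halogen on this ring, such as an amine or a carboxylic acid, would compare.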